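A methoxy group gives way to hydrogen

The source may report more compounds than this note shows. Statements on the series, on what has been measured and on what is new or still open speak of the compounds shown alone.

In an ADME assay on microsomes from liver (Homo sapiens) for metabolic stability, read by LC-MS, using NADPH, with a stated time of 10 min, tested at 0.1 uM (a lower number here means slower removal, a higher number faster removal of the compound), compound 1 `COc1ccc(F)cc1N1C(=O)CSC1c1cccc(C(=O)NCCCCn2cccn2)c1` gives 421 mL.min-1.g-1 and compound 2 `COc1ccc(F)cc1N1C(=O)CSC1c1cccc(C(=O)NCCCCc2ccccc2)c1` gives 1250 mL.min-1.g-1 while compound 3 `C#Cc1cc(C(=O)NCCCCc2ccccc2)cc(C2SCC(=O)N2c2ccccc2OC)c1` gives 1730 mL.min-1.g-1 so compound 2 sits within the scatter of compound 3 and well clear of compound 1. Compound 4 `O=C(NCCCCc1ccccc1)c1cccc(C2SCC(=O)N2c2cccc(F)c2)c1` differs from compound 2 by hydrogen in place of methoxy on an aromatic carbon with hydrogen in place of methoxy on an aromatic carbon. Going by the values given here, the only measured step is a 3.0-fold higher number from compound 1 to compound 2 (0.47 log units; beyond the scatter) and it concerns the phenyl group, which compound 4 keeps, so it gives no size for this change. The expectation therefore stays anchored on compound 2 at 1250 mL.min-1.g-1 with no move beyond the scatter expected. The estimated step is a 1.3-fold lower number from compound 2 to compound 4 (0.10 log units; within the scatter) and its direction is uncertain. The estimate for compound 4 is 1000 mL.min-1.g-1 (expected range 450 mL.min-1.g-1 to 2200 mL.min-1.g-1).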

Compound 4, intrinsic clearance in microsomes: 1840 mL.min-1.g-1
Compound 4: the middle estimate sits 1.8-fold (0.26 log units) below what was measured; measured number inside the range.
By their numbers in this assay, from the lowest: compound 1; then compounds 2, 3 and 4 (each within the scatter of the next).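

In this assay, hydrogen in place of methoxy, on the aromatic carbon ortho to a large group and para to a fluoro group, gives a 1.5-fold higher number from compound 2 to compound 4 (0.17 log units; within the scatter) and so stays within the scatter. At this position the methoxy group is therefore not needed to hold the number where compound 2 stands, and its loss brings no slower removal. No evidence here bears on the reason for this result.

From the compounds shown here alone, whether a chloro or hydroxyl group at this carbon would move the number remains open. So does whether hydrogen in place of methoxy would read the same with the 1H-pyrazol-1-yl chain end of compound 1.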